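The compounds below may be only part of what the source reports. "The series", "measured", "known", "first", "only" and "open" are said of these compounds alone.

In a functional assay on MCF7 cells (Homo sapiens) for inhibition, read by CCK-8 assay, with a stated time of 48 h (on this read-out lower numbers stand for stronger inhibition and higher numbers for weaker inhibition), compound 1 `COc1cc(-c2ccnc3cc(-c4ccc5c(ccn5C)c4)nn23)cc(OC)c1OC` gives 3 nM and compound 2 `COc1ccc(-c2cc3nccc(-c4cc(OC)c(OC)c(OC)c4)n3n2)cc1N` gives 27 nM, so compound 2 holds the higher, weaker of the two numbers. Compound 3 `COc1cc(-c2ccnc3cc(-c4ccc(C(C)(C)C)cc4)nn23)cc(OC)c1OC` has not yet been measured. It differs from compound 2 in a single group: 4-(tert-butyl)phenyl in place of 3-amino-4-methoxyphenyl on an aromatic carbon. In words, 4-(tert-butyl)phenyl stands in place of 3-amino-4-methoxyphenyl, on an aromatic carbon of a five-membered aromatic ring with 2 nitrogen.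

For the measured compounds named here, only one measured step bears on this change. It concerns the same place, where 3-amino-4-methoxyphenyl replaced 1-methyl-1H-indol-5-yl, and it is a 9.0-fold higher number from compound 1 to compound 2 (0.95 log units; beyond the scatter). That single step shows that a new group here can move the number beyond the scatter, but it does not involve 4-(tert-butyl)phenyl. Both measured groups contain nitrogen, whereas the entering group is carbon only, so a further rise of similar size seems more likely than a fall, though this is only a tentative guess. The expected change is a 4.4-fold higher number from compound 2 to compound 3 (0.65 log units; beyond the scatter). In this assay, the estimate for compound 3 is 120 nM, with an expected range of 25 nM to 600 nM.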

Compound 3, half-maximal inhibitory concentration: > 10000 nM
Compound 3 ended at the assay's limit; the forecaster's own chance of this, stated with the estimate: 5%; middle value at least 83-fold (1.92 log units) away from the limit.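

In this assay, compound 3 stands at a limit of the assay, not at a measured number: the limit of > 10000 nM in this assay, at which 1 of the 3 values shown sits.

Even so, the limit is enough to show that 4-(tert-butyl)phenyl gives an at least 370-fold higher number from compound 2 to compound 3 (2.56 log units; beyond the scatter), and that it gives an at least 3300-fold higher number from compound 1 to compound 3 (3.52 log units; beyond the scatter), both much larger than the earlier 9.0-fold higher number from compound 1 to compound 2 (0.95 log units; beyond the scatter). For the compounds shown here, the earlier pair showed only that a new group at this aromatic carbon can shift the number, while compound 3 shows that one replacement here can take a compound from a measured number to the limit of the assay, with the rest of the molecule unchanged.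

The change from compound 2 to compound 3 removes the amino and methoxy groups and adds a tert-butyl group in a single step, so these compounds cannot show which of those differences matters. From the compounds shown here alone, it also stays open whether a plain phenyl, a 4-methoxyphenyl or a 3-aminophenyl at this place would give a number close to that of compound 2 or would also reach the limit.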